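A few compounds are considered here, and "the series" means these few. Any claim that something is new, unique, unknown or untested is made for them only; others in the source may bear on it.

Measured compounds:
compound 1, `COc1cccc(C(=O)NCc2ccc(CNS(=O)(=O)c3ccc(C)cc3)cc2)c1`, 10 nM
compound 2, `Cc1ccc(S(=O)(=O)NCc2ccc(CNC(=O)c3ccncc3)cc2)cc1`, 10 nM
compound 3, `O=C(NCc1ccc(CNS(=O)(=O)c2ccccc2)cc1)c1ccncc1`, 10 nM

Of the compounds shown here, three have been measured in an assay on MDA-MB-231 cells for binding affinity to C-X-C chemokine receptor type 4 (Homo sapiens), read by immunofluorescence and microscopy, with stated times of 10 min and 30 min; a higher number here means that more compound is needed for the effect, a lower number that less compound is needed. In this assay compound 1 gives 10 nM, compound 2 gives 10 nM and compound 3 gives 10 nM, so all three stand level at the digits printed. Compound 2 and compound 1 differ in one place, (3-methoxyphenyl in place of pyridin-4-yl on a carbonyl carbon), and that change gave no change at the digits printed from compound 2 to compound 1 (within the scatter). Compound 2 and compound 3 differ in another place, (hydrogen in place of methyl on an aromatic carbon), and that change gave no change at the digits printed from compound 2 to compound 3 (within the scatter).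

Compound 4, `COc1cccc(C(=O)NCc2ccc(CNS(=O)(=O)c3ccccc3)cc2)c1`, has not yet been measured in this assay. It differs from compound 3 by 3-methoxyphenyl in place of pyridin-4-yl on a carbonyl carbon. Going by the values given here, this is the same change as the one from compound 2 to compound 1, made on a core that differs by hydrogen in place of methyl on an aromatic carbon; the place of the change is described in the same words for both pairs. The earlier step was flat within the scatter, and the change of core from compound 2 to compound 3 was also flat within the scatter. Because no change at the digits printed from compound 2 to compound 1 (within the scatter) showed no movement, the step of no change at the digits printed from compound 3 to compound 4 (within the scatter) is expected to be flat as well. On that basis compound 4 is estimated at 10 nM in this assay, with a likely range from 5 nM to 20 nM.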

Compound 4, effective concentration (reported as EC, without a stated level of effect): > 1000 nM
Compound 4 gave a limit, no number (the forecaster's own chance of this, stated with the estimate: 5%); at least 100-fold (2.00 log units) between middle value and limit.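

Setting 3-methoxyphenyl in place of pyridin-4-yl on the carbonyl carbon gave an at least 100-fold higher number from compound 3 to compound 4 (2.00 log units; beyond the scatter), so this change did not carry from the core of compound 2 to the core of compound 3: the same change on two cores in this assay, no change at the digits printed (within the scatter) from compound 2 to compound 1 and an at least 100-fold higher number (2.00 log units; beyond the scatter) from compound 3 to compound 4, at least 100-fold (2.00 log units) apart, beyond the scatter of two such steps

Read the other way round, hydrogen in place of methyl on an aromatic carbon gave an at least 100-fold higher number from compound 1 to compound 4 (2.00 log units; beyond the scatter), so that change too depends on the group on the carbonyl carbon: the same change on two cores in this assay, no change at the digits printed (within the scatter) from compound 2 to compound 3 and an at least 100-fold higher number (2.00 log units; beyond the scatter) from compound 1 to compound 4, at least 100-fold (2.00 log units) apart, beyond the scatter of two such steps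

In this assay compound 4 gives > 1000 nM, which is a limit of the assay and not a number, so the full size of both steps is not shown, and the four compounds show only that the two changes do not act independently here, not why they fail to do so.

As far as these compounds go, it remains open whether the loss is tied to 3-methoxyphenyl itself or would also appear on the core of compound 3 with other groups on the carbonyl carbon, such as a plain phenyl or a cyclohexyl group. From the compounds shown here alone, it is also open whether a chlorine or a methoxy group in place of the methyl would behave like the methyl or like hydrogen when 3-methoxyphenyl is present.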